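Propylsulfanyl in Place of Sec-Butyl: Compound 2 to Compound 4

The source may hold more compounds than are shown below. What is called first, only, known or untested is meant among the compounds shown, and "the series" means these compounds.

Of the compounds shown here, three have so far been measured in a functional assay for inhibition of sodium/hydrogen exchanger (Oryctolagus cuniculus); a lower number here means a stronger inhibitor, a higher number a weaker inhibitor. Compound 1 `Cc1c(C(=O)N=C(N)N)ccc(Cl)c1S(C)(=O)=O` gives 1300 nM, and compound 3 `Cc1cc(-c2cc(C(F)(F)F)cc(C(F)(F)F)c2)c(S(C)(=O)=O)cc1C(=O)N=C(N)N` gives 2800 nM. Compound 2 `CCC(C)c1cc(C)c(C(=O)N=C(N)N)cc1S(C)(=O)=O` gives 8 nM, the lowest number of the three, and its gaps to both compound 1 and compound 3 lie beyond the scatter. For the measured compounds named here, no pair of measured compounds differs in a single place, so no isolated structural step has been observed on the shared core.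

Compound 4 `CCCSc1cc(C)c(C(=O)N=C(N)N)cc1S(C)(=O)=O` has not yet been measured in this assay. It differs from compound 2 in one place: propylsulfanyl in place of sec-butyl on an aromatic carbon The two chains are alike in size, as the counted difference shows, and the one that enters carries a hydrogen-bond acceptor that the one leaving lacks.

Going by the values given here, with no measured step of this kind to draw on, the expectation is a modest change. The step of a 2.5-fold higher number from compound 2 to compound 4 (0.40 log units; beyond the scatter) is expected to be small, a slight weakening at most, close to the scatter. Compound 4 is therefore estimated to give 20 nM, in a range from 5 nM to 80 nM.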

Compound 4, half-maximal inhibitory concentration: 6.8 nM
Estimate against measurement, compound 4: 2.9-fold (0.47 log units) above; the range from low to high includes it.
By their numbers in this assay, from the lowest: compounds 4 and 2 (each within the scatter of the next); then compound 1; then compound 3.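

For the compounds shown here, the exchange of sec-butyl for propylsulfanyl on an aromatic carbon, ortho to a methylsulfonyl group, gives a 1.2-fold lower number from compound 2 to compound 4 (0.07 log units; within the scatter) in this assay and is the first single-place step seen on this core. At this position, then, a chain with a sulfur and a hydrogen-bond acceptor in it can take the place of an all-carbon chain of the same heavy-atom count with no change that can be told from the scatter. Nothing measured here speaks to why the two chains read alike.

The compounds shown do not tell how a propoxy chain, a longer chain such as pentylsulfanyl, or an amine would read at this place. Going by these compounds alone, with only this one step in hand, it also stays open whether the same exchange would read alike on another core.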